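A few compounds are considered here, and "the series" means these few. Any claim that something is new, unique, unknown or untested is made for them only; others in the source may bear on it.

Working notes on the series.

Among the compounds with values here, compound 1 `C=CCn1c(=O)/c(=C\c2cccc(C)c2)[nH]c(=O)/c1=C\c1ccccc1OC` is the weaker of the two compounds measured so far. In a functional assay on NCI-H1975 cells (Homo sapiens) for cytotoxicity, read by CCK-8 assay, with a stated time of 72 h (a higher number here means a weaker inhibitor, a lower number a stronger inhibitor), compound 1 gives 32800 nM, the highest of the two numbers. The nearest neighbour on that scale is compound 2 `COc1ccccc1/C=c1\c(=O)[nH]/c(=C/c2ccccc2Cl)c(=O)n1C`, which in this assay gives 200 nM, a number lower by a margin well beyond the usual scatter. The two compounds differ in more than one place, so no single structural step can be read from this pair; the values only show that the core tolerates a large range of potency.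

The next compound to be measured is compound 3 `C=CCn1c(=O)/c(=C\c2cccc(Br)c2)[nH]c(=O)/c1=C\c1ccccc1OC`. It differs from compound 1 in one place: bromo in place of methyl on an aromatic carbon. Within the data shown here, no measured pair isolates this kind of change, so the expectation rests on the size of the swap alone, one heavy atom for one heavy atom, with no change in donors, acceptors or charge.

The expected step of a 2.2-fold lower number from compound 1 to compound 3 (0.34 log units; beyond the scatter) is small, toward a somewhat lower number, and may lie within the scatter. Compound 3 is estimated at 15000 nM in this assay, within a range of 4000 nM to 60000 nM.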

Compound 3, half-maximal inhibitory concentration: "not active" (no number reported)
The entry for compound 3 holds no number; there is nothing to compare the estimate with.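

Within the data shown here, compound 3 is reported as "not active" in this assay, with no number, so no step from compound 1 to compound 3 can be read. No measurement at hand bears on this result. The compounds shown leave open how 3-bromophenyl compares with 3-methylphenyl on the numerical scale of this assay.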